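Amide aryl variation on the shared core, toward compound 4

This account rests on a few compounds, and the source may have more. Where it says the series, first, only, none or still open, it means among the compounds named here.

Three amides on the shared core have been measured in a functional assay on HepG2 cells (Homo sapiens) for antiproliferative activity, read by CCK-8 assay, with a stated time of 72 h; on this read-out higher numbers stand for weaker inhibition and lower numbers for stronger inhibition. Compound 1 `O=C(Nc1cccc(-c2oc3cc(-c4ccc(F)cc4)ccc3c(=O)c2O)c1)c1ccc(Cl)cc1` gives 11000 nM. Compound 2 `O=C(Nc1cccc(-c2oc3cc(-c4ccc(F)cc4)ccc3c(=O)c2O)c1)c1ccc(Br)cc1` gives 13900 nM in this assay. Compound 3 `Cc1cc(C)cc(C(=O)Nc2cccc(-c3oc4cc(-c5ccc(F)cc5)ccc4c(=O)c3O)c2)c1` gives 13400 nM in this assay. Compound 1 holds the lowest of the three numbers, yet both steps away from it, a 1.3-fold higher number from compound 1 to compound 2 (0.10 log units; within the scatter) and a 1.2-fold higher number from compound 1 to compound 3 (0.09 log units; within the scatter), stay within the scatter, as does a 1.0-fold lower number from compound 2 to compound 3 (0.02 log units; within the scatter), so none of the three can be set apart.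

Compound 4 `O=C(Nc1cccc(-c2oc3cc(-c4ccc(F)cc4)ccc3c(=O)c2O)c1)c1cc(F)cc(F)c1` differs from compound 1 as follows: 3,5-difluorophenyl in place of 4-chlorophenyl on a carbonyl carbon. The steps bearing on this are a 1.2-fold higher number from compound 1 to compound 3 (0.09 log units; within the scatter), where the 4-chlorophenyl on the carbonyl carbon was likewise exchanged, and a 1.3-fold higher number from compound 1 to compound 2 (0.10 log units; within the scatter), an exchange of halogen. Neither moved the number beyond the scatter. No step beyond the scatter is therefore expected for compound 4 in this assay. The step expected in this assay for compound 4 is a 1.1-fold higher number from compound 1 to compound 4 (0.04 log units; within the scatter). For compound 4 the estimate in this assay is 12000 nM, with a range from 6000 nM to 25000 nM.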

Compound 4, half-maximal inhibitory concentration: 4960 nM
Beside the measured number, compound 4's estimate is 2.4-fold (0.38 log units) above it; measured number below the stated range.
By their numbers in this assay, from the lowest: compound 4; then compounds 1, 3 and 2 (each within the scatter of the next).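

In this assay, the aryl group on the carbonyl carbon, which gave no separable numbers among the three earlier amides, now shows that this position can respond: a 2.2-fold lower number from compound 1 to compound 4 (0.35 log units; beyond the scatter), a 2.7-fold lower number from compound 3 to compound 4 (0.43 log units; beyond the scatter) and a 2.8-fold lower number from compound 2 to compound 4 (0.45 log units; beyond the scatter), each modest but beyond the scatter. The step from the 3,5-dimethylphenyl amide shows that the substitution pattern shared by the 3,5-dimethylphenyl and 3,5-difluorophenyl groups does not by itself give the lower number, as the group on those ring carbons also matters here. Nothing measured on these compounds accounts for the change.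

Going by these compounds, it remains open whether the lower number follows from fluorine itself or from its placement, which a 4-fluorophenyl or a 3,5-dichlorophenyl on the same carbonyl carbon would help to separate. On these data alone, how this position responds to a carboxylic acid or an aminomethyl group on that ring also remains open.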